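This account rests on a few compounds, and the source may have more. Where it says the series, first, only, none or still open, it means among the compounds named here.

Working notes on the series. The compounds share one core and differ in the groups hung on it. In a functional assay on MCF7 cells (Homo sapiens) for antiproliferative activity, read by MTT assay, with a stated time of 72 h (on this read-out higher numbers stand for weaker inhibition and lower numbers for stronger inhibition), compound 1 `O=C1COc2ccc(-c3cnc4ccccc4c3)cc2N1c1ccccc1` gives only a limit, > 40000 nM, so where compound 1 stands on this scale is known only as that bound. Compound 2 `COc1ncc(-c2ccc3c(c2)NC(=O)CO3)cc1NS(=O)(=O)c1ccc(F)cc1` gives 32300 nM in this assay. Compound 3 `O=C1COc2ccc(-c3cccc(NS(=O)(=O)c4ccc(F)cc4)c3)cc2N1` gives 18300 nM in this assay. All three sit at the weak end of the read-out, and compound 1 is the one at the bound itself, (the limit of > 40000 nM in this assay, at which 1 of the 3 values shown sits).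

Compound 4 `O=C1COc2ccc(-c3cnc4ccccc4c3)cc2N1c1ccc(F)cc1` is not yet measured. It differs from compound 1 in one place: fluoro in place of hydrogen on an aromatic carbon. For the measured compounds named here, no measured pair in the set carries this change, so no step for it has been seen. The starting point is a limit rather than a number, and the change is confined to one place on the ring; the expectation is therefore for no step beyond the scatter, with compound 4 expected to sit near the same bound. Compound 4 is estimated at 40000 nM, with a range from 15000 nM to 100000 nM. The step this estimate implies, a number no higher from compound 1 to compound 4 (the limit leaves the size open), is expected to be none beyond the usual scatter, and it is likely that the assay again returns only a limit.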

Compound 4, half-maximal inhibitory concentration: > 40000 nM
Compound 4 ended at the assay's limit; the forecaster's own chance of this, stated with the estimate: 70%; the middle value lies on the limit itself.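

Compound 1 and compound 4 both return only a limit in this assay, so no step can be read between them: the limit of > 40000 nM in this assay, at which 2 of the 4 values shown sit.

The compounds shown leave open whether fluoro in place of hydrogen on this aromatic carbon changes the antiproliferative activity at all, and how far apart compound 1 and compound 4 actually lie.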